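Swapping the ring on the sulfonamide nitrogen in a sulfonamide series

The compounds below may be only part of what the source reports. "The series", "measured", "known", "first", "only" and "open" are said of these compounds alone.

Measured so far:
compound 1 `N#Cc1c(-c2ccccc2)cn(-c2ccc(S(=O)(=O)Nc3ccccn3)cc2)c1NC(N)=O` 4120 nM
compound 2 `N#Cc1c(-c2ccccc2)cn(-c2ccc(S(=O)(=O)Nc3nccs3)cc2)c1NC(=O)CCC(=O)O` 3750 nM

In a functional assay on HepG2 cells (Homo sapiens) for inhibition, read by sulforhodamine B assay, with a stated time of 24 h (a lower number here means a stronger inhibitor, a higher number a weaker inhibitor), compound 2 gives 3750 nM, and compound 1 gives 4120 nM; the two numbers lie within the usual scatter of each other, so neither can be called the stronger. Compound 3 `N#Cc1c(-c2ccccc2)cn(-c2ccc(S(=O)(=O)Nc3ccccn3)cc2)c1NC(=O)CCC(=O)O` differs from compound 2 in one place: pyridin-2-yl in place of 1,3-thiazol-2-yl on a sulfonamide nitrogen. Among the compounds with values here, no pair of measured compounds isolates this swap, so nothing shows its effect directly. The step from compound 2 to compound 3 is expected to be small, a 1.0-fold higher number from compound 2 to compound 3 (0.02 log units; within the scatter), not beyond the scatter in either direction. Compound 3 is therefore estimated at 3900 nM, with a likely range from 1500 nM to 10000 nM.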

Compound 3, half-maximal inhibitory concentration: 3750 nM
Compound 3: middle estimate off by 1.0-fold (0.02 log units), on the high side, and the stated range covers the measured number.
By their numbers in this assay, from the lowest: compounds 2, 3 and 1 (each within the scatter of the next).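

The swap of 1,3-thiazol-2-yl for pyridin-2-yl on a sulfonamide nitrogen can now be read directly in this assay, and it gives no change at the digits printed from compound 2 to compound 3 (within the scatter). Compound 3 also isolates a change on a carbonyl carbon, 2-carboxyethyl in place of amino, which gives a 1.1-fold lower number from compound 1 to compound 3 (0.04 log units; within the scatter). Neither change separates its pair in this assay, and no measurement here offers an explanation. Still open, from the compounds shown here alone, is whether a phenyl ring on the sulfonamide nitrogen, or a longer carboxylic acid chain on the carbonyl carbon, would move the number beyond the scatter.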